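This account rests on a few compounds, and the source may have more. Where it says the series, first, only, none or still open, it means among the compounds named here.

Measured compounds:

compound 1 `COc1ccc(C2CC(c3ccc(NC(=O)c4cc(Cl)ccc4OC)cc3)=NN2)cc1` with 83%
compound 2 `COc1ccc(Cl)cc1C(=O)Nc1ccc(C2=NNC(c3ccccc3[N+](=O)[O-])C2)cc1` with 84.5%
compound 3 `COc1ccc(C2CC(c3ccc(NC(=O)c4cc(Cl)ccc4OC)cc3)=NN2C(C)=O)cc1` with 88.4%

All three were read in a functional assay on the whole organism (plasma, strain albino) for inhibition, with Rattus norvegicus as the target, with stated times of 1 h and 4 h, at a dose of 50 mg/kg by the oral route; on this read-out lower numbers stand for a weaker effect and higher numbers for a stronger effect at the one dose given. The step of a number 1.5 percentage points higher from compound 1 to compound 2 (within the scatter) is the change (2-nitrophenyl in place of 4-methoxyphenyl on a saturated ring carbon). The step of a number 5.4 percentage points higher from compound 1 to compound 3 (within the scatter) is the change (acetyl in place of hydrogen on an amine nitrogen in a ring); this is also how the core of compound 3 differs from the core of compound 1. Compound 3 stands highest of the three numbers, but its gaps to compound 2 and to compound 1 are both within the scatter, so no order among the three can be claimed.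

Among the measured compounds shown here, compound 4 `COc1ccc(Cl)cc1C(=O)Nc1ccc(C2=NN(C(C)=O)C(c3ccccc3[N+](=O)[O-])C2)cc1` has not yet been read in this assay. It differs from compound 3 by 2-nitrophenyl in place of 4-methoxyphenyl on a saturated ring carbon. For the measured compounds named here, this is the same kind of change as the one from compound 1 to compound 2, though the place differs: in compound 3 the saturated ring carbon is also next to the ring atom that bears an acetyl group. Going by the values given here, the one earlier instance of this change moved the read-out by a number 1.5 percentage points higher from compound 1 to compound 2 (within the scatter), a step within the scatter. On that single precedent, a step of about a number 1.1 percentage points higher from compound 3 to compound 4 (within the scatter) is expected from compound 3 to compound 4, because the change from compound 1 to compound 2 gave a number 1.5 percentage points higher from compound 1 to compound 2 (within the scatter). For compound 4 in this assay the estimate is 89.5%, with a range from 79% to 96%.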

Compound 4, a percentage reported as inhibition, in the whole organism at one dose (the size of the read-out at that dose, not a potency): 87.2%
Compound 4: the middle estimate sits 2.3 percentage points above what was measured, and the stated range covers the measured number.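

In this assay, 2-nitrophenyl in place of 4-methoxyphenyl on the saturated ring carbon gives a number 1.2 percentage points lower from compound 3 to compound 4 (within the scatter), and the two instances of this change agree: the same change on two cores in this assay, a number 1.5 percentage points higher (within the scatter) from compound 1 to compound 2 and a number 1.2 percentage points lower (within the scatter) from compound 3 to compound 4, 2.7 percentage points apart, within the scatter of two such steps

Acetyl in place of hydrogen on the ring nitrogen gives a number 2.7 percentage points higher from compound 2 to compound 4 (within the scatter), and this change also reads alike on both cores: the same change on two cores in this assay, a number 5.4 percentage points higher (within the scatter) from compound 1 to compound 3 and a number 2.7 percentage points higher (within the scatter) from compound 2 to compound 4, 2.7 percentage points apart, within the scatter of two such steps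

Every step here lies within the scatter, so the two changes carry from one core to another only in the sense that neither shifts the read-out measurably on either core; this shows neither a real effect of either change nor its direction, and a reading at one dose says nothing about potency.

Still open, on these data alone, is whether any change at these two places can shift this read-out beyond the scatter. A carboxylic acid or an amine on the aryl ring of the saturated ring carbon, or a longer acyl chain in place of acetyl on the ring nitrogen, would test that.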